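The compounds below may be only part of what the source reports. "The series", "measured", "known", "first", "only" and "open" are said of these compounds alone.

Series notes on the ester aryl group of the shared core. Compound 1 `COc1cccc(C(=O)OC2CCC(CN3CCN(c4cc(=O)c5cc(C(F)(F)F)cc([N+](=O)[O-])c5s4)CC3)CC2)c1` and compound 2 `O=C(OC1CCC(CN2CCN(c3cc(=O)c4cc(C(F)(F)F)cc([N+](=O)[O-])c4s3)CC2)CC1)c1ccc2c(c1)OCC2` differ only on the carbonyl carbon of the ester. In an ADME assay on Vero cells (Chlorocebus sabaeus) for cytotoxicity, read by MTT assay, with a stated time of 48 h (on this read-out lower numbers stand for stronger inhibition and higher numbers for weaker inhibition), compound 1 gives > 64 ug/mL, which is a limit of the assay and not a number. In this assay compound 2 gives > 64 ug/mL, likewise only a limit. The step that the two limits leave unreadable from compound 1 to compound 2 is therefore of unreadable size. Compound 2 stands at the limit, with no number to set it against compound 1; both values sit at the limit of > 64 ug/mL in this assay, at which 2 of the 2 values shown sit.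

Compound 3 `O=C(OC1CCC(CN2CCN(c3cc(=O)c4cc(C(F)(F)F)cc([N+](=O)[O-])c4s3)CC2)CC1)c1cccc(F)c1` is the next member. It differs from compound 2 by a group of 7 heavy atoms (6 carbon, 1 fluorine; one six-membered aromatic ring of carbon only) in place of a group of 9 heavy atoms (8 carbon, 1 oxygen; one five-membered non-aromatic ring with 1 hetero atom, one six-membered aromatic ring of carbon only), on a carbonyl carbon. Within the data shown here, the only measured step at this position, a step that the two limits leave unreadable from compound 1 to compound 2, bears on this exchange, and it gives no readable size; so no step beyond the scatter is expected in this assay from the change. Compound 3 is therefore expected to sit at the limit as well, at an estimated 80 ug/mL with a range of 40 ug/mL to 200 ug/mL, which means an expected step that the limit leaves unreadable from compound 2 to compound 3.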

Compound 3, half-maximal inhibitory concentration: > 64 ug/mL
Compound 3 ended at the assay's limit (the forecaster's own chance of this, stated with the estimate: 75%); the middle value does not contradict the limit.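

In this assay compound 3 also stands at a limit of the assay and not a number, so no step from compound 1 or compound 2 to compound 3 can be read: the limit of > 64 ug/mL in this assay, at which 3 of the 3 values shown sit.

The compounds shown leave open whether any group on this carbonyl carbon of the shared core gives a readable value in this assay, and how 3-fluorophenyl compares with the other two groups.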